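This account rests on a few compounds, and the source may have more. Where it says the series, first, only, none or still open, it means among the compounds named here.

Measured in an ADME assay on cells (Hepatocyte, Mus musculus) for cytotoxicity, read by MTT assay, with a stated time of 24 h; a higher number here means that more compound is tolerated, a lower number that less compound is tolerated:
- compound 1 `Cc1ccc(-c2nn(-c3ccccc3)cc2-c2nc3ccccc3n2S(=O)(=O)c2cc(C)ccc2C)cc1`: 231000 nM
- compound 2 `O=S(=O)(c1ccccc1)n1c(-c2cn(-c3ccccc3)nc2-c2ccc(C(F)(F)F)cc2)nc2ccccc21`: 186000 nM

Among the measured compounds shown here, compound 2 lies within the scatter of compound 1, and no step in a single place has been measured. Compound 3 `Cc1ccc(C)c(S(=O)(=O)n2c(-c3cn(-c4ccccc4)nc3-c3ccc(C(F)(F)F)cc3)nc3ccccc32)c1` differs from compound 2 as follows: 2,5-dimethylphenyl in place of phenyl on a sulfonyl sulfur. In short, it has 2,5-dimethylphenyl in place of phenyl on a sulfonyl sulfur. For the measured compounds named here, with no measured step to draw on, no change beyond the scatter is expected in this assay, and compound 2 at 186000 nM remains the reference. The expected step is a 1.1-fold higher number from compound 2 to compound 3 (0.03 log units; within the scatter). The estimate for compound 3 is 200000 nM, with an expected range of 100000 nM to 400000 nM.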

Compound 3, half-maximal cytotoxic concentration: 132000 nM
For compound 3 the middle estimate is 1.5-fold (0.18 log units) above the measured one; the range from low to high includes it.
By their numbers in this assay, from the lowest: compounds 3, 2 and 1 (each within the scatter of the next).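

In this assay, among the compounds shown here, the change to 2,5-dimethylphenyl on the sulfonyl sulfur gives a 1.4-fold lower number from compound 2 to compound 3 (0.15 log units; within the scatter) as the first single-place step at this position, so this position tolerates the two added methyl groups without a change beyond the scatter. At the aromatic carbon, trifluoromethyl in place of methyl gives a 1.8-fold lower number from compound 1 to compound 3 (0.24 log units; within the scatter) and likewise stays inside it. No measurement shown here offers a cause for either step.

Going by these compounds, an amine or a carboxylic acid in place of the aryl group on the sulfonyl sulfur remains open. So does whether any change at these two places reaches beyond the scatter.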